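Three Inactive Bicyclic Lactones and a Stereoisomeric Fourth

A few compounds are considered here, and "the series" means these few. Any claim that something is new, unique, unknown or untested is made for them only; others in the source may bear on it.

Compound 1, `C[C@H]1N=C2C[C@H]3C[C@H](C3(C)C)[C@@]2(C)OC1=O`, in an ADME assay on McCoy cells (Mus musculus) for antiproliferative activity, read by sulforhodamine B assay, with a stated time of 48 h (on this read-out lower numbers stand for stronger inhibition and higher numbers for weaker inhibition), gives > 1800000 nM, a limit of the assay rather than a number.
Compound 2, `CC1(C)[C@@H]2CC3=N[C@@H](CCC(=O)O)C(=O)O[C@@]3(C)[C@H]1C2`, gives in this assay > 1200000 nM, also a limit.
Compound 3, `CC1(C)N=C2C[C@H]3C[C@H](C3(C)C)[C@@]2(C)OC1=O`, gives in this assay > 2000000 nM, again a limit.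

Compound 2 thus stands only at a limit, described by the limit of > 1200000 nM in this assay, at which 1 of the 3 values shown sits, and every other value shown is a limit as well. Compound 4, `C[C@@H]1N=C2C[C@@H]3C[C@@H](C3(C)C)[C@]2(C)OC1=O`, differs from compound 2 by hydrogen in place of carboxymethyl on a saturated chain carbon bound to a saturated ring carbon. For the measured compounds named here, no measured step covers this change. Because compound 2 sits at the limit of > 1200000 nM in this assay, at which 1 of the 3 values shown sits, and nothing shown reaches a number, the step from compound 2 to compound 4 is expected to be none beyond the scatter: a step that the limit leaves unreadable from compound 2 to compound 4. Compound 4 is therefore estimated near 2000000 nM, within 500000 nM to 6000000 nM, most likely reported only as a limit.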

Compound 4, half-maximal inhibitory concentration: > 2000000 nM
Compound 4: only a limit was reported; the forecaster's own chance of this, stated with the estimate: 85%; the middle value sits exactly at the limit.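

Compound 1, compound 2 and compound 4 all give limits of the assay rather than numbers, so the steps to compound 4 from compound 1 and from compound 2 cannot be read. Whether swapping 2-carboxyethyl for methyl or inverting every stereocentre changes activity at all stays open: no compound shown gives a number.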